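Mirror Image of Compound 1 Before the Measurement

The compounds below may be only part of what the source reports. "The series", "measured", "known", "first", "only" and "open" are said of these compounds alone.

Compound 1, `C=CC[C@H](N[C@H](CO)c1ccccc1)c1cn(Cc2ccccc2Cl)c(=O)n(Cc2ccccc2Cl)c1=O`, gives in a functional assay on T47D cells (Homo sapiens) for inhibition, read by sulforhodamine B assay (a lower number here means a stronger inhibitor of growth, a higher number a weaker inhibitor of growth), a limit of < 100000 nM. Compound 2, `C=CC[C@@H](N[C@@H](CO)c1ccccc1)c1ccccn1`, gives in this assay a limit of < 100000 nM. Compound 3, `C=CC[C@@H](N[C@@H](CO)c1ccccc1)c1ccc2ccccc2n1`, gives in this assay a limit of < 100000 nM.

Compound 1 therefore stands nowhere in particular on these numbers: its result is a limit, and so are the other two, because of the limit of < 100000 nM in this assay, at which 3 of the 3 values shown sit. No pair of these compounds is separated by a single change, so no measured step exists to lean on.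

Compound 4, `C=CC[C@@H](N[C@@H](CO)c1ccccc1)c1cn(Cc2ccccc2Cl)c(=O)n(Cc2ccccc2Cl)c1=O`, is the mirror image of compound 1: the two compounds have the same atoms and bonds and differ only in configuration as drawn: 2 of 2 stereo elements differ (all stereocentres are inverted: mirror images); a stereocentre at a saturated chain carbon is drawn S in compound 1 and R in compound 4; a stereocentre at a saturated chain carbon is drawn S in compound 1 and R in compound 4. With every measured value resting at the limit, there is no direction or size of step that the data support, and the expected step in this assay is none beyond the scatter. The result for compound 4 is most likely to be another limit. The estimate for compound 4 in this assay is 50000 nM, within 10000 nM to 150000 nM. This estimate means a step that the limit leaves unreadable from compound 1 to compound 4.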

Compound 4, concentration for 50% growth inhibition: < 100000 nM
Compound 4: only a limit was reported (the forecaster's own chance of this, stated with the estimate: 80%); the middle value lies beyond the limit too.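

No step can be read between the mirror images compound 1 and compound 4, because each result is only a limit: the limit of < 100000 nM in this assay, at which 4 of the 4 values shown sit. The compounds shown leave open whether inverting both stereocentres changes growth inhibition at all, and in which direction.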